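The source may hold more compounds than are shown below. What is called first, only, known or untested is meant among the compounds shown, and "the series" means these compounds.

Compound 1 `Cc1cc(N)c(=O)n(CC(=O)Nc2ccc(Br)cc2)n1`: in a functional assay on HL-60 cells (Homo sapiens), read by calcium flux (a lower number here means that less compound is needed, a higher number that more compound is needed for the effect), compound 1 gives > 50000 nM, a limit of the assay rather than a number.
Compound 2 `COc1cccc(C(=O)Nc2cc(C)nn(CC(=O)Nc3ccc(Br)cc3)c2=O)c1`: in this assay compound 2 gives > 50000 nM, likewise only a limit.

Compound 2 therefore stands at the limit of > 50000 nM in this assay, at which 2 of the 2 values shown sit, without a number of its own. Among the compounds with values here, the one measured step, a step that the two limits leave unreadable from compound 1 to compound 2, has limits at both ends and yields no size. Compound 3 `Cc1cc(NC(=O)c2ccc(Br)cc2)c(=O)n(CC(=O)Nc2ccc(Br)cc2)n1` differs from compound 2 by 4-bromophenyl in place of 3-methoxyphenyl on a carbonyl carbon. Within the data shown here, no measured step resembles this exchange, so the expectation rests on the limits alone. Compound 3 is estimated at 50000 nM, with a range from 10000 nM to 200000 nM, meaning an expected step of a number no higher from compound 2 to compound 3 (the limit leaves the size open), nothing beyond the scatter.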

Compound 3, half-maximal effective concentration: > 50000 nM
Compound 3 ended at the assay's limit (the forecaster's own chance of this, stated with the estimate: 75%); the middle value lies on the limit itself.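

Within the data shown here, no step among compound 1, compound 2 and compound 3 can be read, as all three end at the same limit: the limit of > 50000 nM in this assay, at which 3 of the 3 values shown sit. Still open, on these data alone, is how much of each compound the effect would need, and which change to the shared core would give a readable number.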